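Two bromines on the hydroxyphenyl ring: a small change expected

The source may report more compounds than this note shows. Statements on the series, on what has been measured and on what is new or still open speak of the compounds shown alone.

Compound 1 `O=C(CSc1nnc(-c2ccncc2)n1-c1ccccc1)N/N=C/c1ccc([N+](=O)[O-])cc1` and compound 2 `O=C(CSc1nnc(-c2ccncc2)n1-c1ccccc1)N/N=C/c1ccccc1O` share one core and differ only in the ring attached to the carbon with a double bond to nitrogen. In a functional assay on HCT-116 cells (Homo sapiens) for inhibition, read by MTT assay, with a stated time of 48 h (on this read-out lower numbers stand for stronger inhibition and higher numbers for weaker inhibition), compound 1 gives 10200 nM, and compound 2 gives 7060 nM. Compound 2 stands lowest of the two numbers shown, yet the step of a 1.4-fold lower number from compound 1 to compound 2 (0.16 log units; within the scatter) is within the scatter, so the two compounds cannot be ranked against each other. Compound 3 `O=C(CSc1nnc(-c2ccncc2)n1-c1ccccc1)N/N=C/c1cc(Br)cc(Br)c1O` takes the next step from compound 2: 3,5-dibromo-2-hydroxyphenyl in place of 2-hydroxyphenyl on a carbon with a double bond to nitrogen. For the measured compounds named here, no measured step adds bromine to any ring, so the only guide is the single ring swap, which moved the number by a 1.4-fold lower number from compound 1 to compound 2 (0.16 log units; within the scatter), within the scatter. With so little to build on, the change in this assay is expected to be small, with no direction that can be trusted. Compound 3 is therefore estimated at 5000 nM in this assay, with a range from 1500 nM to 16000 nM. That estimate means an expected step of a 1.4-fold lower number from compound 2 to compound 3 (0.15 log units; within the scatter).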

Compound 3, half-maximal inhibitory concentration: 4500 nM
Estimate against measurement, compound 3: 1.1-fold (0.05 log units) above; measured number inside the range.
By their numbers in this assay, from the lowest: compounds 3, 2 and 1 (each within the scatter of the next, the first and the last beyond it).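

In this assay, adding the two bromines gives a 1.6-fold lower number from compound 2 to compound 3 (0.20 log units; within the scatter), so at this position the dibrominated ring and the plain hydroxyphenyl ring cannot be told apart, even though the entering group is larger by two heavy atoms. The other comparison, with 3,5-dibromo-2-hydroxyphenyl taking the place of 4-nitrophenyl, gives a 2.3-fold lower number from compound 1 to compound 3 (0.36 log units; beyond the scatter); this is the first step among these compounds to clear the scatter, though only modestly, and compound 2 lies within the scatter of both neighbours, so the three rings tried here span only a shallow range. No measurement is available that could account for these numbers.

On these data alone, the ring on this carbon carries only a nitro group, a hydroxyl group or bromines in these compounds, so it remains open how an amine or a carboxylic acid on that ring would fare, and whether a single bromine would read like two. The shared core stays the same throughout, which leaves open whether a longer chain elsewhere on it would shift the number further than these ring swaps do.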